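The compounds below may be only part of what the source reports. "The series", "measured", "known", "first", "only" and "open" are said of these compounds alone.

Working notes on the series: in an ADME assay on MDCKII-LE cells (Canis lupus familiaris) for permeability (a higher number here means that the compound crosses the layer faster, a lower number that the compound crosses the layer more slowly), compound 1 `N#CCCCN([C@H](CCC(F)(F)F)C(N)=O)S(=O)(=O)c1ccc(Cl)cc1` gives 27.6 10^-6 cm/s, and compound 2 `N#C[C@H]1C[C@@H]1CN([C@H](CCC(F)(F)F)C(N)=O)S(=O)(=O)c1ccc(Cl)cc1` gives 21.5 10^-6 cm/s, so compound 1 stands within the scatter of the only other measured compound. Compound 3 `N#C[C@H]1C[C@H](CN([C@H](CCC(F)(F)F)C(N)=O)S(=O)(=O)c2ccc(Cl)cc2)C1` is still unmeasured. Its difference from compound 1 is 3-cyanocyclobutyl in place of 2-cyanoethyl on a saturated chain carbon bound to a sulfonamide nitrogen, which places 3-cyanocyclobutyl in place of 2-cyanoethyl on a saturated chain carbon bound to a sulfonamide nitrogen. Within the data shown here, the one measured step that bears on this change is a 1.3-fold lower number from compound 1 to compound 2 (0.11 log units; within the scatter), where 2-cyanocyclopropyl replaces 2-cyanoethyl at the same place. Among the measured compounds shown here, no measured compound yet carries the four-membered ring, so this reading rests on a single pair. No step beyond the scatter is therefore expected in this assay. The expected step is a 1.2-fold lower number from compound 1 to compound 3 (0.08 log units; within the scatter). Compound 3 is estimated at 23 10^-6 cm/s, with an expected range of 12 10^-6 cm/s to 40 10^-6 cm/s.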

Compound 3, apparent permeability: 24.9 10^-6 cm/s
Beside the measured number, compound 3's estimate is 1.1-fold (0.03 log units) below it; the measured number falls inside the stated range.
By their numbers in this assay, from the lowest: compounds 2, 3 and 1 (each within the scatter of the next).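

In this assay, on a saturated chain carbon bound to a sulfonamide nitrogen, 3-cyanocyclobutyl in place of 2-cyanoethyl gives a 1.1-fold lower number from compound 1 to compound 3 (0.04 log units; within the scatter) and so, like 2-cyanocyclopropyl, leaves no step beyond the scatter. The direct comparison of the two rings gives a 1.2-fold higher number from compound 2 to compound 3 (0.06 log units; within the scatter) and shows that, among compounds 1, 2 and 3, this read-out does not separate the open chain, the three-membered ring and the four-membered ring at this place. Nothing measured here explains why these three groups cannot be told apart.

Still open, on these data alone, is whether an amine or a carboxylic acid in place of the nitrile would give a step beyond the scatter at this place. Also open, as far as these compounds go, is how a longer chain bearing the nitrile, or the other stereoisomer of 3-cyanocyclobutyl, would read.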